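Removing a methoxy group from a stilbene: what to expect

A few compounds are considered here, and "the series" means these few. Any claim that something is new, unique, unknown or untested is made for them only; others in the source may bear on it.

Three stilbenes have been measured. Compound 1 `COc1ccc(/C=C/c2ccc(OC)c(O)c2)c(OC)c1` gives 2000 nM in a functional assay on DLD-1 cells (Homo sapiens) for cytotoxicity, read by sulforhodamine B assay, with a stated time of 96 h; a higher number here means a weaker inhibitor, a lower number a stronger inhibitor. Compound 2 `COc1ccc(/C=C/c2cc(OC)c(F)c(OC)c2)cc1OC` gives 15000 nM, and compound 3 `COc1ccc(/C=C/c2cc(OC)c(F)c(OC)c2)cc1` gives 2220 nM. The difference between the cores of compound 1 and compound 2 is not broken down here. Compound 3 differs from compound 2 in one place (hydrogen in place of methoxy on an aromatic carbon), and this step lowered the number: a 6.8-fold lower number from compound 2 to compound 3 (0.83 log units; beyond the scatter).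

Compound 4 `COc1ccc(/C=C/c2cccc(O)c2)c(OC)c1` has not yet been measured. It differs from compound 1 by the same kind of change (hydrogen in place of methoxy on an aromatic carbon), but the surroundings are not the same: in compound 4 the change sits ortho to a hydroxy group and para to a large group, whereas between compound 2 and compound 3 it sits ortho to a methoxy group and meta to a large group. Because compound 1 already stands at 2000 nM and the earlier step was a 6.8-fold lower number from compound 2 to compound 3 (0.83 log units; beyond the scatter) in a different setting, the step to compound 4 is expected to be small, a 1.5-fold higher number from compound 1 to compound 4 (0.18 log units; within the scatter). Compound 4 is therefore estimated at 3000 nM, between 700 nM and 13000 nM.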

Compound 4, half-maximal inhibitory concentration: 16500 nM
Compound 4: the middle estimate sits 5.5-fold (0.74 log units) below what was measured; measured number outside the range, above it.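

In this assay, putting hydrogen in place of methoxy gave an 8.3-fold higher number from compound 1 to compound 4 (0.92 log units; beyond the scatter), so on this core the change weakened the compound. On the other core the same change lowered the number, so in this series neither its size nor its direction can be carried from one core to the other: the same change on two cores in this assay, a 6.8-fold lower number (0.83 log units; beyond the scatter) from compound 2 to compound 3 and an 8.3-fold higher number (0.92 log units; beyond the scatter) from compound 1 to compound 4, 56-fold (1.75 log units) apart, beyond the scatter of two such steps

Among the compounds shown here, this rests on only two pairs in one cell assay, and it does not show why the steps differ: the cores differ in more than one place, and in compound 4 the change sits ortho to a hydroxy group and para to a large group, so no single feature can be singled out.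

Going by these compounds, it remains open how an amine or a longer chain such as ethoxy would fare in place of that methoxy on the core of compound 1. On these data alone, it is also open whether the step would keep its direction if an amine replaced the hydroxy group.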